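The compounds below may be only part of what the source reports. "The series", "measured", "known", "first", "only" and "open" are said of these compounds alone.

Compound 1 `CC(O)(COc1ccccc1C(F)(F)F)C(=O)Nc1ccc(S(F)(F)(F)(F)F)cc1` and compound 2 `CC(O)(COc1ccccc1OC(F)(F)F)C(=O)Nc1ccc(S(F)(F)(F)(F)F)cc1` share one core and differ only by the change (trifluoromethoxy in place of trifluoromethyl on an aromatic carbon). In a functional assay on CWR22R cells (Homo sapiens) for antiproliferative activity, read by propidium iodide staining, with a stated time of 96 h (a lower number here means a stronger inhibitor, a higher number a weaker inhibitor), compound 1 gives 1400 nM, while compound 2 gives 7300 nM, so the change produced a 5.2-fold higher number from compound 1 to compound 2 (0.72 log units; beyond the scatter). Compound 3 `CC(O)(COc1ccccc1C(F)(F)F)C(=O)Nc1cccc(S(F)(F)(F)(F)F)c1` is built from the same atoms as compound 1 but joined differently; how the two cores differ is not broken down here. In this assay compound 3 gives 34900 nM. Compound 4 `CC(O)(COc1ccccc1OC(F)(F)F)C(=O)Nc1cccc(S(F)(F)(F)(F)F)c1` is related to compound 3 by the change (trifluoromethoxy in place of trifluoromethyl on an aromatic carbon), the same change as before, at the same kind of place. Because compound 1 to compound 2 gave a 5.2-fold higher number from compound 1 to compound 2 (0.72 log units; beyond the scatter), a comparable weakening is expected from compound 3 to compound 4, that is a 3.4-fold higher number from compound 3 to compound 4 (0.54 log units; beyond the scatter). Compound 4 is therefore estimated at 120000 nM, expected between 40000 nM and 400000 nM.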

Compound 4, half-maximal inhibitory concentration: 30000 nM
Compound 4: the middle estimate sits 4.0-fold (0.60 log units) above what was measured, outside the stated range (below it).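

In this assay, putting trifluoromethoxy in place of trifluoromethyl gave a 1.2-fold lower number from compound 3 to compound 4 (0.07 log units; within the scatter), so the weakening seen on the core of compound 1 did not carry over to the core of compound 3. Among these compounds, the two cores respond differently to this change, so a step measured on one is a poor guide to the other: the same change on two cores in this assay, a 5.2-fold higher number (0.72 log units; beyond the scatter) from compound 1 to compound 2 and a 1.2-fold lower number (0.07 log units; within the scatter) from compound 3 to compound 4, 6.1-fold (0.78 log units) apart, beyond the scatter of two such steps This rests on only two pairs of compounds, and it does not show why the cores differ or how the change would behave on a further core. The compounds shown leave open how other groups at this place, such as a nitrile, a chlorine atom or a methyl group, would behave on either core.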